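This account rests on a few compounds, and the source may have more. Where it says the series, first, only, none or still open, it means among the compounds named here.

Compound 1 `Cc1nc(C(=O)Nc2ccc(Cl)c(-c3nnc4c(Cl)cccn34)c2)cs1` carries an amide on a shared core, and the group attached to the carbonyl carbon is the part that changes in this series. In a functional assay on MCF7 cells (Homo sapiens) for antiproliferative activity, read by MTT assay, with a stated time of 72 h (on this read-out lower numbers stand for stronger inhibition and higher numbers for weaker inhibition), compound 1 gives only a limit of the assay, > 100000 nM, and not a number. Compound 2 `Cc1cc(Cl)ccc1C(=O)Nc1ccc(Cl)c(-c2nnc3c(Cl)cccn23)c1` replaces that group with 4-chloro-2-methylphenyl; in this assay compound 2 likewise gives only a limit, > 100000 nM. Both values are limits, so the step that the two limits leave unreadable from compound 1 to compound 2 cannot be read in size or direction. What the measurements do show is the limit of > 100000 nM in this assay, at which 2 of the 2 values shown sit. Compound 3 `O=C(Nc1ccc(Cl)c(-c2nnc3c(Cl)cccn23)c1)c1ccccc1` has not yet been measured; it differs from compound 1 in one place: phenyl in place of 2-methyl-1,3-thiazol-4-yl on a carbonyl carbon. Among the measured compounds shown here, the only measured step at this position is the unreadable one, so no direction can be taken from it, and the two limits together point toward another value at the limit. Compound 3 is therefore expected to give an estimated 100000 nM, with a range from 30000 nM to 300000 nM. The expected step of a number no higher from compound 1 to compound 3 (the limit leaves the size open) is, in effect, none.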

Compound 3, half-maximal inhibitory concentration: > 100000 nM
Compound 3: only a limit was reported (the forecaster's own chance of this, stated with the estimate: 80%); the middle value sits exactly at the limit.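

In this assay compound 3 gives > 100000 nM, which is a limit and not a number. Among the compounds shown here, no new step can therefore be read between compound 3 and compound 1 or compound 2, in size or direction. The picture stays the same: the limit of > 100000 nM in this assay, at which 3 of the 3 values shown sit. Going by these compounds, what remains open is whether any group on the carbonyl carbon of this shared core gives a measurable number in this assay.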